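Ring-nitrogen substituent swap and permeability: compound 3 to 4

The source may hold more compounds than are shown below. What is called first, only, known or untested is meant among the compounds shown, and "the series" means these compounds.

Measured set in an ADME assay on Caco-2 cells (Homo sapiens) for permeability, in the apical to basolateral direction; on this read-out higher numbers stand for higher permeability and lower numbers for lower permeability:
compound 1 `Cn1cncc1CN1CC(N(CC2CCN(C(=O)NC(C)(C)C)CC2)S(=O)(=O)c2ccccn2)Cc2cc(C#N)ccc21` gives 0.6 10^-6 cm/s
compound 2 `CCCC(=O)N1CCC(CN(C2Cc3cc(C#N)ccc3N(Cc3cncn3C)C2)S(=O)(=O)c2ccccn2)CC1` gives 0.5 10^-6 cm/s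
compound 3 `Cn1cnc(S(=O)(=O)N2CCC(CN(C3Cc4cc(C#N)ccc4N(Cc4cncn4C)C3)S(=O)(=O)c3ccccn3)CC2)c1` gives 0.1 10^-6 cm/s

Compound 3 stands lowest of the three numbers in this assay. The steps onto it, a 6.0-fold lower number from compound 1 to compound 3 (0.78 log units; beyond the scatter) and a 5.0-fold lower number from compound 2 to compound 3 (0.70 log units; beyond the scatter), both lie beyond the scatter, whereas a 1.2-fold lower number from compound 1 to compound 2 (0.08 log units; within the scatter) lies within it.

Compound 4 `CCNC(=O)N1CCC(CN(C2Cc3cc(C#N)ccc3N(Cc3cncn3C)C2)S(=O)(=O)c2ccccn2)CC1` differs from compound 3 by ethylcarbamoyl in place of (1-methyl-1H-imidazol-4-yl)sulfonyl on an amine nitrogen in a ring. The two measured steps onto compound 3 bear directly on this change, as each exchanged a carbamoyl or carbonyl group on the same ring nitrogen for the sulfonyl group; compound 4 reverses that exchange. A step of similar size in the upward direction is therefore expected in this assay for compound 4, that is a 5.0-fold higher number from compound 3 to compound 4 (0.70 log units; beyond the scatter).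

Compound 4 is estimated at 0.5 10^-6 cm/s, with a range from 0.2 10^-6 cm/s to 1.2 10^-6 cm/s.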

Compound 4, apparent permeability: 0.6 10^-6 cm/s
For compound 4 the middle estimate is 1.2-fold (0.08 log units) below the measured one, and the stated range covers the measured number.
By their numbers in this assay, from the lowest: compound 3; then compounds 2, 1 and 4 (each within the scatter of the next).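

Ethylcarbamoyl in place of (1-methyl-1H-imidazol-4-yl)sulfonyl on this ring nitrogen gives (a 6.0-fold higher number from compound 3 to compound 4 (0.78 log units; beyond the scatter)) in this assay, so among the four compounds the low number stays with the sulfonyl compound alone. The carbonyl-linked groups are not told apart: ethylamino in place of propyl gives (a 1.2-fold higher number from compound 2 to compound 4 (0.08 log units; within the scatter)), and ethyl in place of tert-butyl gives (no change at the digits printed from compound 1 to compound 4 (within the scatter)). Nothing here gives a reason for the gap between the sulfonyl and carbonyl-linked groups.

Open, on these data alone, is whether a plain methylsulfonyl on this ring nitrogen would stay as low as compound 3, which would separate the sulfonyl link from the imidazole ring.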